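The source may hold more compounds than are shown below. What is called first, only, known or untested is meant among the compounds shown, and "the series" means these compounds.

Measured so far:
- Compound 1, `CC(C)[C@H](C(=O)Nc1ccc(F)cn1)c1ccc(Cl)cc1`: in a functional assay on CHO cells for agonist activity at Free fatty acid receptor 2 (Homo sapiens), read by cAMP accumulation (a higher number here means a weaker inhibitor, a lower number a stronger inhibitor), compound 1 gives 1300 nM.
- Compound 2, `CC(C)[C@H](C(=O)Nc1nncs1)c1ccc(Cl)cc1`: in this assay compound 2 gives 12000 nM.
- Compound 3, `CC(C)[C@H](C(=O)Nc1ccon1)c1ccc(Cl)cc1`: in this assay compound 3 gives 36000 nM.

All three share one core and differ only in the ring attached to the amide-type nitrogen. Compound 3 stands at the highest number of the three, that is, the weakest; its nearest neighbour is compound 2, and the gap is a 3.0-fold higher number from compound 2 to compound 3 (0.48 log units; beyond the scatter), while the widest gap is a 28-fold higher number from compound 1 to compound 3 (1.44 log units; beyond the scatter).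

Compound 4, `CC(C)[C@H](C(=O)NC1=NC(=O)CS1)c1ccc(Cl)cc1`, is the next step from compound 3: a group of 6 heavy atoms (3 carbon, 1 nitrogen, 1 oxygen, 1 sulfur; one five-membered non-aromatic ring with 2 hetero atoms) in place of a group of 5 heavy atoms (3 carbon, 1 nitrogen, 1 oxygen; one five-membered aromatic ring with 2 hetero atoms), on an amide-type nitrogen. Going by the values given here, the steps that bear on it are the two ring exchanges already seen, a 9.2-fold higher number from compound 1 to compound 2 (0.97 log units; beyond the scatter) and a 28-fold higher number from compound 1 to compound 3 (1.44 log units; beyond the scatter), both changing the same amide-type ring and both beyond the scatter. They show that this ring matters, but none of them involves a non-aromatic ring, so the direction here is uncertain; the nearest comparison is compound 2, which also carries a sulfur-containing ring and sits at 12000 nM. Compound 4 is therefore expected at 25000 nM, with a range from 5000 nM to 100000 nM, a step of a 1.4-fold lower number from compound 3 to compound 4 (0.16 log units; within the scatter) that is estimated to stay within the scatter.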

Compound 4, half-maximal inhibitory concentration: 20000 nM
Estimate against measurement, compound 4: 1.3-fold (0.10 log units) above; the range from low to high includes it.
By their numbers in this assay, from the lowest: compound 1; then compounds 2, 4 and 3 (each within the scatter of the next, the first and the last beyond it).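

In this assay, putting a non-aromatic ring on the amide-type nitrogen gives a 1.8-fold lower number from compound 3 to compound 4 (0.26 log units; within the scatter), and measured against the aromatic ring of compound 2 it gives a 1.7-fold higher number from compound 2 to compound 4 (0.22 log units; within the scatter), so at this position a five-membered ring need not be aromatic to read in the same range as these two. The six-membered aromatic ring of compound 1 remains apart from all three five-membered rings, and the new ring adds a 15-fold higher number from compound 1 to compound 4 (1.19 log units; beyond the scatter). Nothing available explains why these rings read as they do.

Still open, from the compounds shown here alone, is whether the lower number of compound 1 goes with its six-membered ring or with its fluorine, which a plain pyridin-2-yl or a phenyl ring could help separate. Going by these compounds, how a non-aromatic six-membered ring such as piperidine would read also remains open.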